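The compounds below may be only part of what the source reports. "The series", "measured", "known", "first", "only" and "open" are said of these compounds alone.

Compound 2 `c1cncc(CNCCCCN(C[C@H]2Cc3ccccc3CN2)[C@H]2CCCc3cccnc32)c1` gives 15.3 nM in a functional assay on cells for antagonist activity at C-X-C chemokine receptor type 4 (Homo sapiens), read by fluorescence and calcium flux, with stated times of 25 min and 90 s (on this read-out higher numbers stand for weaker inhibition and lower numbers for stronger inhibition), the lowest of the three numbers seen so far. Compound 3 `c1ccc2c(c1)CN[C@@H](CN(CCCCNC1CCCCC1)[C@H]1CCCc3cccnc31)C2` gives 75.2 nM and compound 1 `c1ccc(CN(CCCCN(C[C@H]2Cc3ccccc3CN2)[C@H]2CCCc3cccnc32)Cc2ccccn2)nc1` gives 664 nM in this assay. Compound 4 `C(=C/CN(C[C@H]1Cc2ccccc2CN1)[C@H]1CCCc2cccnc21)\CNC1CCOCC1` is not yet measured; it differs from compound 2 by 3-((oxan-4-yl)amino)prop-1-en-1-yl in place of 3-(((pyridin-3-yl)methyl)amino)propyl on a saturated chain carbon bound to an amine nitrogen. For the measured compounds named here, the one measured step that bears on this change is a 4.9-fold higher number from compound 2 to compound 3 (0.69 log units; beyond the scatter), where cyclohexyl replaced (pyridin-3-yl)methyl on an amine nitrogen. The oxan-4-yl group entering in compound 4 is also a six-membered non-aromatic ring, so a rise of similar size is expected, with extra uncertainty from the double bond in the chain. Compound 4 is therefore estimated at 70 nM, between 20 nM and 250 nM. That estimate corresponds to an expected step of a 4.6-fold higher number from compound 2 to compound 4 (0.66 log units; beyond the scatter).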

Compound 4, half-maximal inhibitory concentration: 15.5 nM
Compound 4: the middle estimate sits 4.5-fold (0.65 log units) above what was measured; measured number outside the range, below it.
By their numbers in this assay, from the lowest: compounds 2 and 4 (each within the scatter of the next); then compound 3; then compound 1.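

In this assay, the pyridine ring of compound 2 is not required at this position: the change to compound 4 gives a 1.0-fold higher number from compound 2 to compound 4 (0.01 log units; within the scatter) despite replacing the aromatic ring with oxan-4-yl. The step of a 4.9-fold lower number from compound 3 to compound 4 (0.69 log units; beyond the scatter) shows that a six-membered non-aromatic ring on this chain need not give a number as high as that of compound 3, although the ring oxygen and the double bond change together. No measured evidence explains these results. Whether the ring oxygen or the double bond accounts for that step remains open. A saturated propyl chain carrying oxan-4-yl, or a piperidin-4-yl ring with nitrogen in place of the oxygen, would help separate them.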